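The source may report more compounds than this note shows. Statements on the series, on what has been measured and on what is new or still open speak of the compounds shown alone.

Of the compounds shown here, three on one shared core have been measured in a functional assay on HT-29 cells (Homo sapiens) for inhibition, with a stated time of 72 h; a higher number here means a weaker inhibitor, a lower number a stronger inhibitor. Compound 1 (`COc1ccc(S(=O)(=O)N2CCc3cccc(-c4ccco4)c32)cc1`) gives 62.5 nM, compound 2 (`COc1ccc(S(=O)(=O)N2CCc3cccc(-c4ccncc4)c32)cc1`) gives 87.5 nM, and compound 3 (`COc1ccc(S(=O)(=O)N2CCc3cccc(-c4ccccc4)c32)cc1`) gives 96.5 nM. Compound 3 therefore stands within the scatter of both others: a 1.1-fold higher number from compound 2 to compound 3 (0.04 log units; within the scatter) and a 1.5-fold higher number from compound 1 to compound 3 (0.19 log units; within the scatter) are small, as is a 1.4-fold higher number from compound 1 to compound 2 (0.15 log units; within the scatter).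

Compound 4 (`COc1ccc(S(=O)(=O)N2CCc3cccc(-c4ccc(O)cc4)c32)cc1`) has not yet been measured. It differs from compound 3 by hydroxy in place of hydrogen on an aromatic carbon, para to a large group, turning phenyl into 4-hydroxyphenyl: hydroxy in place of hydrogen on an aromatic carbon. The measured steps bear on this only loosely, since each swaps one whole aromatic ring for another and none adds a group to the phenyl. With a 1.5-fold higher number from compound 1 to compound 3 (0.19 log units; within the scatter) and a 1.1-fold higher number from compound 2 to compound 3 (0.04 log units; within the scatter) both inside the scatter, the expected 1.0-fold higher number from compound 3 to compound 4 (0.02 log units; within the scatter) is no step beyond the scatter, in neither direction. For the measured compounds named here, no measured compound carries hydroxy, so the range is kept wide. Compound 4 is estimated at 100 nM, with an expected range of 35 nM to 300 nM.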

Compound 4, half-maximal inhibitory concentration: 133 nM
Beside the measured number, compound 4's estimate is 1.3-fold (0.12 log units) below it; measured number inside the range.
By their numbers in this assay, from the lowest: compounds 1, 2, 3 and 4 (each within the scatter of the next, the first and the last beyond it).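

In this assay, for the compounds shown here, hydroxy on the phenyl ring, para to a large group, gives the first change that adds a group to this ring rather than swapping the whole ring, and the step of a 1.4-fold higher number from compound 3 to compound 4 (0.14 log units; within the scatter) stays within the scatter. Going by these compounds alone, the step of a 1.5-fold higher number from compound 2 to compound 4 (0.18 log units; within the scatter) also stays within the scatter, while the step of a 2.1-fold higher number from compound 1 to compound 4 (0.33 log units; beyond the scatter) is the first in this set to pass beyond it, though only modestly, so the position tolerates this added group without a clear loss against phenyl. Nothing available here accounts for these small differences.

On these data alone, whether an amine, a carboxylic acid or a methoxy group in the same place would move the number beyond the scatter remains open. As far as these compounds go, it is also open how a furan-2-yl ring would respond to the same hydroxy.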